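The source may hold more compounds than are shown below. What is called first, only, known or untested is meant among the compounds shown, and "the series" means these compounds.

Among the compounds with values here, the two measured members share a core bearing a urea-linked aryl group. Compound 1 is `COc1cc(-c2nn(-c3cccc(NC(=O)Nc4cc(C(F)(F)F)cc(C(F)(F)F)c4)c3)cc2-c2ccncc2)ccc1Cl` and compound 2 is `O=C(Nc1cccc(-n2cc(-c3ccncc3)c(-c3ccc(Cl)c(O)c3)n2)c1)Nc1ccc(Cl)c(Cl)c1`. In a functional assay on MDA-MB-435 cells (Homo sapiens) for inhibition, read by sulforhodamine B assay, with a stated time of 48 h (on this read-out higher numbers stand for weaker inhibition of growth and lower numbers for stronger inhibition of growth), compound 1 gives 1990 nM, the lowest of the two numbers in hand. Compound 2 gives 6050 nM in this assay, a higher number that lies beyond the scatter; the two structures differ in more than one place, so this pair says nothing about any single change.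

Compound 3, `COc1cc(-c2nn(-c3cccc(NC(=O)Nc4cccc(C(F)(F)F)c4)c3)cc2-c2ccncc2)ccc1Cl`, is not yet measured in this assay. Against compound 1 the difference is hydrogen in place of trifluoromethyl on an aromatic carbon; the ring that carries the change still holds a trifluoromethyl group. Within the data shown here, no measured pair isolates such a change, so there is no measured step to lean on. The expectation for compound 3 is a modest loss, with the step of a 1.6-fold higher number from compound 1 to compound 3 (0.21 log units; within the scatter) estimated to fall near the edge of the scatter, toward a higher number. The estimate for compound 3 in this assay is 3200 nM, within a range from 1500 nM to 7000 nM.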

Compound 3, concentration for total growth inhibition: 2140 nM
The estimate for compound 3 lay 1.5-fold (0.17 log units) above the measured number; measured number inside the range.
By their numbers in this assay, from the lowest: compounds 1 and 3 (each within the scatter of the next); then compound 2.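

Hydrogen in place of trifluoromethyl on this aromatic carbon, meta to a large group and meta to a trifluoromethyl group, is the first single change in the series that can be read, and it comes to a 1.1-fold higher number from compound 1 to compound 3 (0.03 log units; within the scatter) in this assay. At this place, then, the 4 heavy atoms of one trifluoromethyl group can leave without a step beyond the scatter, so compound 1 and compound 3 cannot be told apart on this read-out, with a trifluoromethyl group still on the ring in both. No measurement in hand bears on what lies behind this result.

The compounds shown leave open what the remaining trifluoromethyl group contributes, since this step speaks only to the place where the change was made, and compound 2 differs from compound 1 and compound 3 in more than one place. They also leave open whether a step this small would hold for an amine, a carboxylic acid or a nitrile on the same aromatic carbon, since this place has been read only with hydrogen and trifluoromethyl.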